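A few compounds are considered here, and "the series" means these few. Any claim that something is new, unique, unknown or untested is made for them only; others in the source may bear on it.

For the measured compounds named here, compound 1 `Oc1ccc(O)c(-c2cc(-c3ccc(Cl)cc3)nn2-c2ccccc2)c1` gives the lowest number of the three measured so far in a functional assay on cells (Cancer cell lines, Homo sapiens) for cytotoxicity, read by sulforhodamine B assay, with a stated time of 48 h (a lower number here means a stronger inhibitor of growth, a higher number a weaker inhibitor of growth), namely 34600 nM. Compound 2 `NS(=O)(=O)c1ccc(-n2nc(-c3ccc(Cl)cc3)cc2-c2cc(O)ccc2O)cc1` gives 35500 nM, and compound 3 `CC(=O)NS(=O)(=O)c1ccc(-n2nc(-c3ccc(Cl)cc3)cc2-c2cc(O)ccc2O)cc1` gives 93900 nM. The steps seen, a 1.0-fold higher number from compound 1 to compound 2 (0.01 log units; within the scatter), a 2.7-fold higher number from compound 1 to compound 3 (0.43 log units; beyond the scatter) and a 2.6-fold higher number from compound 2 to compound 3 (0.42 log units; beyond the scatter), all concern substitution on the phenyl; none touches the 2,5-dihydroxyphenyl. Compound 4 `O=C1C=CC(=O)C(c2cc(-c3ccc(Cl)cc3)nn2-c2ccccc2)=C1` differs from compound 1 in exactly that part: a group of 8 heavy atoms (6 carbon, 2 oxygen; one six-membered non-aromatic ring of carbon only) in place of a group of 8 heavy atoms (6 carbon, 2 oxygen; one six-membered aromatic ring of carbon only), on an aromatic carbon. Going by the values given here, no measured step covers this kind of change, so the series gives no size or direction for it, and the expectation rests on compound 1 alone. For compound 4 the expected value in this assay is therefore 25000 nM, within a deliberately wide range from 5000 nM to 90000 nM. The step this estimate implies is a 1.4-fold lower number from compound 1 to compound 4 (0.14 log units; within the scatter).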

Compound 4, concentration for total growth inhibition: 55800 nM
Beside the measured number, compound 4's estimate is 2.2-fold (0.35 log units) below it; the measured number falls inside the stated range.
By their numbers in this assay, from the lowest: compounds 1, 2, 4 and 3 (each within the scatter of the next, the first and the last beyond it).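

In this assay, the aromatic 2,5-dihydroxyphenyl on this carbon gives way to a non-aromatic six-membered carbon ring with 0 hydrogen-bond donors instead of 2, and the result is a 1.6-fold higher number from compound 1 to compound 4 (0.21 log units; within the scatter) in a step that stays within the scatter. This position therefore accepts the change without a shift that can be read, whereas earlier steps addressed only the phenyl. Nothing available bears on the reason.

As far as these compounds go, whether an amine or a carboxylic acid on this ring carbon would keep the number in this range remains open. Also open, from the compounds shown here alone, is whether the sulfamoyl and acetylsulfamoyl steps carry over to compound 4.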